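From cyclopropyl to tert-butyl on the side chain

The source may report more compounds than this note shows. Statements on the series, on what has been measured and on what is new or still open speak of the compounds shown alone.

Of the compounds shown here, three sharing one core have been measured in a functional assay on a cell-free system (plasma, Homo sapiens), with a stated time of 3 min; a higher number here means a weaker inhibitor, a lower number a stronger inhibitor. Compound 1 `O=C(NCc1cc(Cl)ccc1-n1cnnn1)[C@@H]1C[C@@H]2C[C@@H]2N1C(=O)[C@H](O)CC1CC1` gives 1700 nM, compound 2 `O=C(NCc1cc(Cl)ccc1-n1cnnn1)[C@@H]1C[C@@H]2C[C@@H]2N1C(=O)[C@H](O)C1CCCCC1` gives 600 nM, and compound 3 `O=C(NCc1cc(Cl)ccc1-n1cnnn1)[C@@H]1C[C@H]2C[C@H]2N1C(=O)[C@H](O)CC1CC1` gives 850 nM. The number for compound 3 lies within the usual scatter of both other numbers, so it cannot be ranked against either.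

The next compound, compound 4 `CC(C)(C)C[C@@H](O)C(=O)N1[C@@H]2C[C@@H]2C[C@H]1C(=O)NCc1cc(Cl)ccc1-n1cnnn1`, alters one group of compound 3: tert-butyl in place of cyclopropyl on a saturated chain carbon, two bonds along the chain from a carbonyl carbon and an oxygen on a saturated carbon. Cut one bond further out, this is cyclopropylmethyl becoming neopentyl.

Among the compounds with values here, two measured steps bear on this change. The closer one alters the same group, although it does so on the other configuration of the core: cyclohexyl in place of cyclopropylmethyl gives a 2.8-fold lower number from compound 1 to compound 2 (0.45 log units; beyond the scatter). The second step changes configuration alone and gives a 2.0-fold lower number from compound 1 to compound 3 (0.30 log units; within the scatter). Neither step is the same swap, so they offer only a rough guide.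

Taking compound 2 and its step of a 2.8-fold lower number from compound 1 to compound 2 (0.45 log units; beyond the scatter) as that guide, a small move towards a lower number is expected, namely a 1.9-fold lower number from compound 3 to compound 4 (0.28 log units; within the scatter). For compound 4 the estimated value in this assay is 450 nM, with an expected range from 130 nM to 1500 nM.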

Compound 4, half-maximal inhibitory concentration: 520 nM
The estimate for compound 4 lay 1.2-fold (0.06 log units) below the measured number; the measured number falls inside the stated range.
By their numbers in this assay, from the lowest: compounds 4, 2, 3 and 1 (each within the scatter of the next, the first and the last beyond it).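

In this assay the swap of cyclopropyl for tert-butyl gives a 1.6-fold lower number from compound 3 to compound 4 (0.21 log units; within the scatter) and so leaves the two numbers within the scatter of each other. Within the data shown here, this shows, for the first time on the configuration of compound 3, that the side chain can lose its three-membered ring and end in a branched, ring-free group without a change that can be told from the scatter. Among these compounds, the only earlier swap of this side chain, cyclohexyl in place of cyclopropylmethyl, was read on the other configuration, so this step is the first direct reading on this one, and the two configurations have to be kept apart: the fact that compounds 1 and 3 differ only in the configuration as drawn.

All the side chains shown end in groups of carbon and hydrogen alone, so it stays open how an amine or a carboxylic acid at this place, or a longer straight chain, would read in this assay. Going by these compounds, it also stays open whether tert-butyl would give a similar result on the configuration of compound 1.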